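A para-fluoro on the phenyl tail of compound 1

The source may hold more compounds than are shown below. What is called first, only, known or untested is meant among the compounds shown, and "the series" means these compounds.

Three hydrazides sharing the same propanoyl hydrazine motif have been measured in a functional assay on HEK293 cells for antagonist activity at P2X purinoceptor 7 (Homo sapiens), read by fluorescence, with a stated time of 2 h; a lower number here means a stronger inhibitor, a higher number a weaker inhibitor. Compound 1 `O=C(CCc1ccccc1)NNc1c(Cl)cncc1Cl` gives 650 nM, the lowest of the three numbers. Compound 3 `Cc1cccc(C)c1NNC(=O)CCc1ccccc1` gives 900 nM, which sits within the scatter of the number for compound 1, so no order between these two can be claimed. Compound 2 `O=C(CCc1ccccc1)NNc1c(Cl)cccc1Cl` gives 1400 nM, a gap from compound 1 that lies beyond the scatter. Among the measured compounds shown here, none of these pairs differs in only one place, so the three values show only that the pyridine-bearing compound 1 and the dimethylphenyl compound 3 sit close together, with compound 2 further up.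

Compound 4 `O=C(CCc1ccc(F)cc1)NNc1c(Cl)cncc1Cl` has not yet been measured in this assay. It departs from compound 1 by fluoro in place of hydrogen on an aromatic carbon, para to a large group, on the phenyl ring at the end of the chain; read one bond further out, phenyl becomes 4-fluorophenyl. For the measured compounds named here, no measured pair here shows what such a change does. He therefore expects a step from compound 1 to compound 4 of a 1.2-fold lower number from compound 1 to compound 4 (0.07 log units; within the scatter), small and not clearly beyond the scatter, in either direction. The estimate for compound 4 in this assay is 550 nM, with a range from 200 nM to 1500 nM.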

Compound 4, half-maximal inhibitory concentration: 900 nM
Beside the measured number, compound 4's estimate is 1.6-fold (0.21 log units) below it; low and high end bracket the measured number.
By their numbers in this assay, from the lowest: compounds 1, 3, 4 and 2 (each within the scatter of the next, the first and the last beyond it).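

In this assay, fluoro in place of hydrogen on the phenyl ring at the end of the chain gives a 1.4-fold higher number from compound 1 to compound 4 (0.14 log units; within the scatter), so this change cannot be said to have either strengthened or weakened the compound. This is the only pair shown that differs in one place, and it adds what the three earlier compounds could not show: at this aromatic carbon, para to a large group, on the core of compound 1, a fluoro leaves the number within the scatter of the hydrogen parent. No supporting measurement is available that could explain this result, so it stands as an observation about a single pair, without a cause.

As far as these compounds go, what remains open is whether a larger group at the same place, such as chloro, methoxy or trifluoromethyl, would produce a step beyond the scatter, and whether an amine or a carboxylic acid there would be accepted at all. From the compounds shown here alone, it is also open whether 4-fluorophenyl would behave in the same way on the cores of compound 2 and compound 3, or with a longer chain leading to the ring.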